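The compounds below may be only part of what the source reports. "The series", "measured", "known", "first", "only" and "open" are said of these compounds alone.

Measured so far in a physicochemical assay for acid dissociation:

compound 1 `CC(C)(C)c1ccc(Oc2ccc3c(NCCCNCc4ccco4)ccnc3c2)cc1`: 9.28
compound 2 `COc1ccc(F)cc1CNCCCNc1ccnc2cc(Cc3ccc(F)cc3Cl)ccc12`: 9.47
compound 3 `FC(F)(F)c1cc(-c2ccc3c(NCCCNCc4ccco4)ccnc3c2)cc(C(F)(F)F)c1`: 9.47

Compound 2 stands level with compound 3 at the digits given, the two together at the top of the three numbers. Its nearest neighbour is compound 3, with no change at the digits given, which is within the scatter; its furthest is compound 1, whose number is lower, but that gap too lies within the scatter. Across the three measured compounds, then, this assay has so far returned one value within its own noise.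

Compound 4 `COc1ccc(F)cc1CNCCCNc1ccnc2cc(Cc3ccc(F)cc3)ccc12` has not yet been measured in this assay. It differs from compound 2 in one place: hydrogen in place of chloro on an aromatic carbon. Put another way, the 2-chloro-4-fluorobenzyl of compound 2 becomes a 4-fluorobenzyl in compound 4.

For the measured compounds named here, no step between two measured compounds of this set shows what this particular change does. The three compounds measured do, however, carry quite different groups elsewhere on the shared core and still sit within the scatter of one another, from compound 1 at 9.28 to compound 3 at 9.47. The step is therefore expected to be small, with no direction beyond the scatter, estimated as no change at the digits printed from compound 2 to compound 4 (within the scatter). On that basis compound 4 is expected to give about 9.47, in a range from 9.2 to 9.75.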

Compound 4, acid dissociation constant: 9.47
Compound 4: the middle estimate sits on the measured number at the digits printed; measured number inside the range.
By their numbers in this assay, from the lowest: compounds 1, 2, 3 and 4 (each within the scatter of the next).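

In this assay, for the compounds shown here, the first step in this set that changes one place alone gives no change at the digits printed from compound 2 to compound 4 (within the scatter) when the chloro ortho to a large group on the 2-chloro-4-fluorobenzyl is replaced by hydrogen. Compounds 1, 2 and 3 differ from one another in more than one place, so they could not isolate this position; this pair shows that removing this one heavy atom, while the fluoro and the rest of the molecule stay the same, leaves the read-out unchanged within the scatter. Nothing available accounts for this result, so the step stands as an observation about this single pair.

The compounds shown leave open whether this position would remain as quiet in this read-out if it carried an amine or a carboxylic acid rather than chloro or hydrogen. They also leave open whether the same exchange would give a similar step on a compound with a longer chain joining the shared core to its amine, since this one pair cannot show how far the result extends.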